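Three limits and a fourth amide-bearing analog

This account rests on a few compounds, and the source may have more. Where it says the series, first, only, none or still open, it means among the compounds named here.

Of the compounds shown here, three built on a shared core have been tested in a functional assay on A549 cells (Homo sapiens) for inhibition, read by MTT assay, with a stated time of 24 h; on this read-out lower numbers stand for stronger inhibition and higher numbers for weaker inhibition. Compound 1 `CCOC(=O)C1=Cc2ccccc2OC1(OCc1cn(CC(=O)Nc2cccc(F)c2)nn1)C(F)(F)F` carries a ((3-fluorophenyl)carbamoyl)methyl group on the aromatic nitrogen, and in this assay compound 1 reaches only the limit of the assay at > 150000 nM. Compound 2 `CCOC(=O)C1=Cc2ccccc2OC1(OCc1cn(CC(=O)Nc2ccccc2Br)nn1)C(F)(F)F` likewise gives only a limit, > 150000 nM. Compound 3 `CCOC(=O)C1=Cc2ccccc2OC1(OCc1cn(-c2cccc(C(F)(F)F)c2)nn1)C(F)(F)F`, bearing 3-(trifluoromethyl)phenyl on that nitrogen, also stops at the limit, > 150000 nM. The steps a step that the two limits leave unreadable from compound 1 to compound 2, a step that the two limits leave unreadable from compound 1 to compound 3 and a step that the two limits leave unreadable from compound 2 to compound 3 cannot be sized because of the limit of > 150000 nM in this assay, at which 3 of the 3 values shown sit.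

Compound 4 `CCOC(=O)C1=Cc2ccccc2OC1(OCc1cn(CC(=O)Nc2ccc(I)cc2Cl)nn1)C(F)(F)F` differs from compound 3 by ((2-chloro-4-iodophenyl)carbamoyl)methyl in place of 3-(trifluoromethyl)phenyl on an aromatic nitrogen. Its substituent is of the same amide type as those of compound 1 and compound 2. For the measured compounds named here, no measured step has a readable size, so nothing beyond the scatter is expected in this assay, and the result will most likely again be a limit. Compound 4 is estimated at 200000 nM, with a range from 100000 nM to 600000 nM. The expected step is a step that the limit leaves unreadable from compound 3 to compound 4.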

Compound 4, half-maximal inhibitory concentration: 22300 nM
Compound 4: middle estimate off by 9.0-fold (0.95 log units), on the high side, and the stated range ends above it.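

In this assay, this aromatic nitrogen can carry a group that gives a readable value: ((2-chloro-4-iodophenyl)carbamoyl)methyl in place of 3-(trifluoromethyl)phenyl gives an at least 6.7-fold lower number from compound 3 to compound 4 (0.82 log units; beyond the scatter). The amide type alone is not enough, as compound 1 and compound 2 also carry it and each stays at a limit. Within that type, 2-chloro-4-iodophenyl in place of 2-bromophenyl gives an at least 6.7-fold lower number from compound 2 to compound 4 (0.82 log units; beyond the scatter), and in place of 3-fluorophenyl it gives an at least 6.7-fold lower number from compound 1 to compound 4 (0.82 log units; beyond the scatter).

These steps give only minimum sizes, and the steps among compound 1, compound 2 and compound 3 cannot be read: the limit of > 150000 nM in this assay, at which 3 of the 4 values shown sit. On these data alone, it remains open whether the chlorine or the iodine of compound 4 matters more, and whether a methoxy group or a carboxylic acid in place of the iodine would keep a readable value.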